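The source may report more compounds than this note shows. Statements on the series, on what has been measured and on what is new or still open speak of the compounds shown alone.

Three compounds have been measured in a physicochemical assay for solubility, using the shake flask method, measured as kinetic solubility, with a stated time of 20 h, at pH 2; on this read-out lower numbers stand for lower solubility and higher numbers for higher solubility:

- Compound 1 `COc1cccnc1Nc1cc2[nH]c(-c3cccc(C(F)(F)F)c3)nc2cn1`: 116000 nM
- Compound 2 `FC(F)(F)c1cccc(-c2nc3cnc(Nc4cnccn4)cc3[nH]2)c1`: 155000 nM
- Compound 3 `Fc1ccc(Nc2cc3[nH]c(-c4cccc(C(F)(F)F)c4)nc3cn2)nc1`: < 5000 nM

Compound 3 is the lowest of the three, yet it gives only a limit: the limit of < 5000 nM in this assay, at which 1 of the 3 values shown sits. Compound 4 `FC(F)(F)c1ccc(Nc2cc3[nH]c(-c4cccc(C(F)(F)F)c4)nc3cn2)nc1` has not yet been measured. It carries trifluoromethyl in place of fluoro on an aromatic carbon, turning 5-fluoropyridin-2-yl into 5-(trifluoromethyl)pyridin-2-yl: trifluoromethyl in place of fluoro on an aromatic carbon.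

Among the compounds with values here, no measured step makes this exact exchange. The nearest guides are changes of the whole group on the same nitrogen. These are an at least 23-fold lower number from compound 1 to compound 3 (1.36 log units; beyond the scatter) and an at least 31-fold lower number from compound 2 to compound 3 (1.49 log units; beyond the scatter), both large, while a 1.3-fold higher number from compound 1 to compound 2 (0.13 log units; within the scatter) stays within the scatter. Given the two large steps to compound 3, compound 4, as its closest relative, is expected to stay near compound 3 rather than rise towards compound 1 or compound 2. No step beyond the scatter is expected in this assay, in either direction. The estimated step is a step that the limit leaves unreadable from compound 3 to compound 4. Compound 4 is estimated at 4000 nM, with an expected range from 1500 nM to 12000 nM.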

Compound 4, solubility: < 5000 nM
Compound 4: only a limit was reported; the forecaster's own chance of this, stated with the estimate: 70%; the middle value lies beyond the limit too.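

In this assay compound 4 gives only a limit, as compound 3 does, so the step of trifluoromethyl in place of fluoro on an aromatic carbon cannot be read: the limit of < 5000 nM in this assay, at which 2 of the 4 values shown sit. The earlier compounds shown here showed this low end for 5-fluoropyridin-2-yl alone; now 5-(trifluoromethyl)pyridin-2-yl on the same nitrogen falls there too, with an at least 31-fold lower number from compound 2 to compound 4 (1.49 log units; beyond the scatter) and an at least 23-fold lower number from compound 1 to compound 4 (1.36 log units; beyond the scatter). Both groups at this position, para to a large group, therefore sit apart from the two compounds with readable values.

Going by these compounds, how far compound 3 and compound 4 lie past the limit, and whether they differ at all, stays open. Also open, on these data alone, is whether an amine or a carboxylic acid in place of trifluoromethyl on this aromatic carbon would bring the number back towards those of compound 1 and compound 2.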